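An Amino Group in Place of tert-Butyl

The source may report more compounds than this note shows. Statements on the series, on what has been measured and on what is new or still open speak of the compounds shown alone.

Compound 1 `COc1ccc(NC(=O)c2cc(=O)[nH]c3cc(Br)ccc23)cc1`, compound 2 `COc1ccc2c(C(=O)Nc3cc(F)cc(F)c3)cc(=O)[nH]c2c1` and compound 3 `CC(C)(C)c1ccc(-c2ccc3c(C(=O)Nc4cccc(F)c4)cc(=O)[nH]c3c2)cc1` share one core and differ in the groups hung on it. In a functional assay on KYSE-410 cells (Homo sapiens) for antiproliferative activity, read by MTT assay, with a stated time of 72 h (a lower number here means a stronger inhibitor, a higher number a weaker inhibitor), compound 1 gives > 20000 nM, which is a limit of the assay and not a number. Compound 2 gives > 20000 nM in this assay, again only a limit. Compound 3 gives > 20000 nM, once more a limit. Within the data shown here, compound 3 therefore has no place on a scale of numbers: it sits together with the other two at the limit of > 20000 nM in this assay, at which 3 of the 3 values shown sit, so no order among the three can be read and no step between measured compounds exists.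

Compound 4 `Nc1ccc(-c2ccc3c(C(=O)Nc4cccc(F)c4)cc(=O)[nH]c3c2)cc1` is the unmeasured partner of compound 3: amino in place of tert-butyl on an aromatic carbon. Nothing measured speaks to how such a change acts here, since compound 3 itself gives > 20000 nM and offers no number to move from. Compound 4 is therefore expected to show a step of an at least 1.3-fold lower number from compound 3 to compound 4 (0.12 log units; that floor lies within the scatter) that amounts to no change beyond the scatter, and most likely it too will return only a limit. The estimate for compound 4 in this assay is 15000 nM, with a range from 3000 nM to 60000 nM.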

Compound 4, half-maximal inhibitory concentration: > 20000 nM
Compound 4 gave a limit, no number; the forecaster's own chance of this, stated with the estimate: 75%; middle value at least 1.3-fold (0.12 log units) from the limit.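

In this assay compound 4 gives > 20000 nM, which is a limit of the assay and not a number. Among these compounds, compound 3 also gave only a limit, so no step between compound 3 and compound 4 can be read. The compounds shown leave open whether amino in place of tert-butyl changes the activity at all, and which groups on the shared core would give a number: the limit of > 20000 nM in this assay, at which 4 of the 4 values shown sit.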